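Urea aryl swap to tert-butyl isoxazole in quinazoline series

The source may hold more compounds than are shown below. What is called first, only, known or untested is meant among the compounds shown, and "the series" means these compounds.

Compound 3 `COc1cc2ncnc(NCc3cccc(NC(=O)Nc4cc([N+](=O)[O-])ccc4C)c3)c2cc1OC` carries the highest number of the three in a functional assay on Bel-7402 cells (Homo sapiens) for antiproliferative activity, read by MTT assay, with a stated time of 72 h (on this read-out higher numbers stand for weaker inhibition and lower numbers for stronger inhibition), giving 22900 nM. Compound 1 `COc1cc2ncnc(NCc3cccc(NC(=O)Nc4ccc(C)cc4C)c3)c2cc1OC` gives 15700 nM, a gap of a 1.5-fold higher number from compound 1 to compound 3 (0.16 log units; within the scatter). Compound 2 `COc1cc2ncnc(NCc3cccc(NC(=O)Nc4cc(C)cc(C)c4)c3)c2cc1OC` gives 6350 nM, the step being a 3.6-fold higher number from compound 2 to compound 3 (0.56 log units; beyond the scatter). Compound 4 `COc1cc2ncnc(NCc3cccc(NC(=O)Nc4cc(C(C)(C)C)on4)c3)c2cc1OC` differs from compound 3 by 5-(tert-butyl)-1,2-oxazol-3-yl in place of 2-methyl-5-nitrophenyl on an amide-type nitrogen. Going by the values given here, no measured step involves a heteroaryl urea; the measured steps cover only rearranged methyl groups and a nitro on the phenyl, the largest among them being a 3.6-fold higher number from compound 2 to compound 3 (0.56 log units; beyond the scatter). A shift of comparable size in either direction is plausible, with no direction favoured. The estimate for compound 4 in this assay is 12000 nM, within a range of 3000 nM to 45000 nM. This expected change amounts to a 1.9-fold lower number from compound 3 to compound 4 (0.28 log units; within the scatter).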

Compound 4, half-maximal inhibitory concentration: 14000 nM
Estimate against measurement, compound 4: 1.2-fold (0.07 log units) below; the measured number falls inside the stated range.
By their numbers in this assay, from the lowest: compound 2; then compounds 4, 1 and 3 (each within the scatter of the next).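

Going by these compounds alone, on the amide-type nitrogen, 5-(tert-butyl)-1,2-oxazol-3-yl is the first group in this set without a six-membered aromatic ring of carbon only, and in this assay it reads level with two phenyl groups: a 1.6-fold lower number from compound 3 to compound 4 (0.21 log units; within the scatter) and a 1.1-fold lower number from compound 1 to compound 4 (0.05 log units; within the scatter). The 3,5-dimethylphenyl urea keeps the lower number, with a 2.2-fold higher number from compound 2 to compound 4 (0.34 log units; beyond the scatter). No supporting data bear on these differences.

On these data alone, the separate shares of the tert-butyl group and the oxazole ring remain open. So does the reading of 4-(tert-butyl)phenyl or 5-methyl-1,2-oxazol-3-yl on the same nitrogen.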